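Chloro for Methoxy on the Aryl Ring

This account rests on a few compounds, and the source may have more. Where it says the series, first, only, none or still open, it means among the compounds named here.

Compound 1 `COc1ccc(/C=N\NC(=S)NC(C)(C)CCC[C@](C)(O)[C@@H]2CC=C(C)CC2)cc1`: 6730 nM
Compound 2 `CC1=CC[C@@H]([C@@](C)(O)CCCC(C)(C)NC(=S)N/N=C\c2ccccc2[N+](=O)[O-])CC1`: 20400 nM

In a functional assay on NCI/ADR cells (Homo sapiens) for cytotoxicity, read by sulforhodamine B assay (on this read-out lower numbers stand for stronger inhibition of growth and higher numbers for weaker inhibition of growth), compound 1 gives 6730 nM, the lowest of the two numbers shown, with compound 2 as its only neighbour. Compound 3 `CC1=CC[C@@H]([C@@](C)(O)CCCC(C)(C)NC(=S)N/N=C\c2ccc(Cl)cc2)CC1` differs from compound 1 by chloro in place of methoxy on an aromatic carbon. Within the data shown here, the one measured step, a 3.0-fold higher number from compound 1 to compound 2 (0.48 log units; beyond the scatter), also alters the group on that aryl ring, but to a different group, so nothing here speaks directly to chloro in place of methoxy. In the absence of a direct comparison, a step within the usual scatter is expected: a 1.2-fold higher number from compound 1 to compound 3 (0.08 log units; within the scatter). Compound 3 is accordingly estimated at 8000 nM, between 3000 nM and 25000 nM.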

Compound 3, concentration for 50% growth inhibition: 7580 nM
Compound 3: middle estimate off by 1.1-fold (0.02 log units), on the high side; low and high end bracket the measured number.
By their numbers in this assay, from the lowest: compounds 1 and 3 (each within the scatter of the next); then compound 2.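

In this assay a change of a 1.1-fold higher number from compound 1 to compound 3 (0.05 log units; within the scatter) shows that 4-chlorophenyl can replace 4-methoxyphenyl on the shared core with a difference inside the scatter. With a 2.7-fold lower number from compound 2 to compound 3 (0.43 log units; beyond the scatter) alongside it, the 2-nitrophenyl of compound 2 stands apart from the other two aryl groups, on the side of weaker growth inhibition. No measurement at hand explains these numbers.

Compound 2 differs in both the group and its place on the ring, so these compounds cannot separate those two changes. From the compounds shown here alone, how an amine or a carboxylic acid on that same aromatic carbon would read remains open.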